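Side-chain amine variation on the shared core

A few compounds are considered here, and "the series" means these few. Any claim that something is new, unique, unknown or untested is made for them only; others in the source may bear on it.

Compound 1 `CN(C)CCn1c(N)c(-c2nc3ccccc3[nH]2)c2nc(C#N)c(C#N)nc21` serves as the reference point of this small set. In a functional assay on Raji cells (Homo sapiens) for antiproliferative activity, read by MTT assay, with a stated time of 48 h (a lower number here means a stronger inhibitor, a higher number a weaker inhibitor), compound 1 gives 8320 nM, the highest of the two numbers shown. Compound 3 `CN1CCN(CCCn2c(N)c(-c3nc4ccccc4[nH]3)c3nc(C#N)c(C#N)nc32)CC1` gives 2620 nM, and the step of a 3.2-fold lower number from compound 1 to compound 3 (0.50 log units; beyond the scatter) counts as modest. Compound 2 `CCCn1c(N)c(-c2nc3ccccc3[nH]2)c2nc(C#N)c(C#N)nc21` reports > 50000 nM, which is a limit of the assay rather than a number. Compound 2 thus sits at the limit of > 50000 nM in this assay, at which 1 of the 3 values shown sits. Consequently the step of an at least 6.0-fold higher number from compound 1 to compound 2 (0.77 log units; beyond the scatter) is known only as a bound, and the step of an at least 19-fold lower number from compound 2 to compound 3 (1.28 log units; beyond the scatter) likewise.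

Compound 4 `N#Cc1nc2c(-c3nc4ccccc4[nH]3)c(N)n(CCCN3CCCCC3)c2nc1C#N` has not yet been measured. Its difference from compound 1 is this: (piperidin-1-yl)methyl in place of dimethylamino on a saturated chain carbon, two bonds along the chain from an aromatic nitrogen. Among the compounds with values here, of the measured steps, the one from compound 1 to compound 3 bears most directly on it, since there too a cyclic amine enters in place of dimethylamino on the same chain carbon; the step from compound 1 to compound 2, where the chain amine is lost altogether, shows what removal costs and argues that keeping a tertiary amine on the chain matters. For compound 4 a modest lowering of the number relative to compound 1 is therefore expected, a 2.8-fold lower number from compound 1 to compound 4 (0.44 log units; beyond the scatter), with an estimated 3000 nM in a range from 1200 nM to 8000 nM.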

Compound 4, half-maximal inhibitory concentration: 3380 nM
For compound 4 the middle estimate is 1.1-fold (0.05 log units) below the measured one; low and high end bracket the measured number.
By their numbers in this assay, from the lowest: compounds 3 and 4 (each within the scatter of the next); then compound 1. At a limit, above all of these: compound 2.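

In this assay, 3-(piperidin-1-yl)propyl in place of 2-(dimethylamino)ethyl gives a 2.5-fold lower number from compound 1 to compound 4 (0.39 log units; beyond the scatter), so a second cyclic amine on the longer chain also lies beyond the scatter from the reference. Piperidin-1-yl in place of 4-methylpiperazin-1-yl gives a 1.3-fold higher number from compound 3 to compound 4 (0.11 log units; within the scatter), which leaves these two cyclic amines indistinguishable in this assay, so the second ring nitrogen and its methyl of compound 3 are not needed to reach this range. Piperidin-1-yl in place of hydrogen on the chain gives an at least 14-fold lower number from compound 2 to compound 4 (1.17 log units; beyond the scatter), a bound only, and compound 2 itself stands at a limit of the assay and not at a number: the limit of > 50000 nM in this assay, at which 1 of the 4 values shown sits.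

Compounds 3 and 4 differ from compound 1 in both the amine and the chain length, so the compounds shown do not tell whether the ring or the longer chain accounts for their lower numbers; a 3-(dimethylamino)propyl chain would separate the two. Also open, from the compounds shown here alone, is how far the amine itself can vary on this chain, for example morpholin-4-yl or a primary amine, and whether a still longer chain carries the same result.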